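Fluoro removal on the fused core of compound 1

The source may hold more compounds than are shown below. What is called first, only, known or untested is meant among the compounds shown, and "the series" means these compounds.

Going by the values given here, compound 1 `CCC(Nc1nnc(-c2ccc(OC)cc2)o1)[C@H]1CC[C@@H](c2ccnc3c(F)cc(F)cc32)CC1` is the more stable of the two compounds measured so far: in an ADME assay on microsomes from liver (Rattus norvegicus) for metabolic stability, with a stated time of 10 min, tested at 0.5 uM (a lower number here means that less of the compound is left, a higher number that more of the compound is left), compound 1 gives 52%, the highest number of the pair, and compound 2 `C[C@@H](c1nc2cc(F)ccc2[nH]1)[C@H]1CC[C@@H](c2ccnc3ccc(F)cc32)CC1` gives 0% in this assay, a number that lies well beyond the scatter below compound 1. Compound 2 differs from compound 1 in more than one place, so nothing can be read from the pair about any single change.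

Compound 3 `CCC(Nc1nnc(-c2ccc(OC)cc2)o1)[C@H]1CC[C@@H](c2ccnc3ccc(F)cc32)CC1` differs from compound 1 in one place: hydrogen in place of fluoro on an aromatic carbon. Among the compounds with values here, no measured pair shows this change on its own. A moderate decrease in this assay is expected for compound 3, of a size near the edge of the usual scatter, as the step of a number 12 percentage points lower from compound 1 to compound 3 (beyond the scatter). Compound 3 is therefore estimated at 40% in this assay, with a range of 20% to 60%.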

Compound 3, percent of the compound remaining: 45%
Beside the measured number, compound 3's estimate is 5 percentage points below it; the measured number falls inside the stated range.
By their numbers in this assay, from the lowest: compound 2; then compounds 3 and 1 (each within the scatter of the next).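

In this assay, going by these compounds alone, hydrogen in place of fluoro on an aromatic carbon, ortho to a fused ring, gives a number 7 percentage points lower from compound 1 to compound 3 (within the scatter), the first step that isolates a single place. At this position, with the rest of compound 1 kept, including the fluoro group meta to it, the read-out does not separate the fluoro compound from the hydrogen compound, so the fluoro group here is not shown to matter for the percent remaining. No supporting data on the fate of either compound accompany this result.

As far as these compounds go, whether a larger replacement at this carbon, such as chloro, nitrile or trifluoromethyl, would also stay within the scatter remains open. Also open, from the compounds shown here alone, is what removing the remaining fluoro group on the shared core would do, alone or together with this change.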